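Swapping Methoxy for a Methylpiperidine on a Shared Core

This account rests on a few compounds, and the source may have more. Where it says the series, first, only, none or still open, it means among the compounds named here.

Compound 1 `COc1ccc(Nc2ncc3c(n2)N(C2CCCC2)CC(=O)N3C)cc1` was tested in a functional assay on HCT-116 cells (Homo sapiens) for inhibition, read by MTT assay, with a stated time of 48 h (on this read-out higher numbers stand for weaker inhibition and lower numbers for stronger inhibition), where compound 1 gives 12300 nM. Among the measured compounds shown here, of the two numbers measured in this assay, compound 1 has the highest, but its only neighbour, compound 2 `CCN1C(=O)CN(C2CCCC2)c2nc(Nc3ccc(OC)cc3)ncc21`, which in this assay gives 11000 nM, differs by a 1.1-fold lower number from compound 1 to compound 2 (0.05 log units; within the scatter), so the two cannot be told apart. That single measured step is a methyl in place of hydrogen on a chain carbon bound to the amide-type nitrogen, not the aromatic carbon where compound 3 `CC1CCN(c2ccc(Nc3ncc4c(n3)N(C3CCCC3)CC(=O)N4C)cc2)CC1` differs: 4-methylpiperidin-1-yl in place of methoxy on an aromatic carbon. For the measured compounds named here, no measured step touches that position, so nothing here points to a direction, and the one small step offers only a scale. Compound 3 is therefore expected to land close to compound 1, the step of a 1.0-fold lower number from compound 1 to compound 3 (0.01 log units; within the scatter) being an estimate. For compound 3 the expected value in this assay is 12000 nM, within a range from 4000 nM to 36000 nM.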

Compound 3, half-maximal inhibitory concentration: 25300 nM
Beside the measured number, compound 3's estimate is 2.1-fold (0.32 log units) below it, and the stated range covers the measured number.
By their numbers in this assay, from the lowest: compounds 2 and 1 (each within the scatter of the next); then compound 3.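

In this assay, the aromatic carbon para to a large group now has a measured step of its own: 4-methylpiperidin-1-yl in place of methoxy gives a 2.1-fold higher number from compound 1 to compound 3 (0.31 log units; beyond the scatter), a modest move towards weaker inhibition. This shows that the number can respond to a change at this position, and that this larger group, with its six-membered non-aromatic ring, brings no gain in inhibition over methoxy. Nothing available explains why the number rises.

A single swap cannot separate the contribution of the ring from that of its methyl group or its nitrogen. Going by these compounds, it remains open how a plain piperidine, a morpholine or a carboxylic acid on this same carbon would compare with methoxy, and whether any group here could give stronger inhibition.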